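The source may report more compounds than this note shows. Statements on the series, on what has been measured and on what is new or still open speak of the compounds shown alone.

Measured in a functional assay on MDA-MB-231 cells (Homo sapiens) for cytotoxicity, read by MTT assay, with a stated time of 72 h; on this read-out lower numbers stand for stronger inhibition and higher numbers for weaker inhibition:
compound 2 `CN(C)Cc1ccc2nc(NC(=O)N/N=C/c3cn(Cc4ccccc4)c4ccccc34)sc2c1` gives 1340 nM
compound 3 `CC1CCN(Cc2ccc3nc(NC(=O)N/N=C/c4cn(Cc5ccccc5)c5ccccc45)sc3c2)CC1` gives 2850 nM
compound 1 `CN(C)Cc1ccc2nc(NC(=O)N/N=C3\C(=O)Nc4ccc(Cl)cc43)sc2c1` gives "not determined" (no result reported)

All three compounds share one core. Compound 1 carries a different hydrazone partner and was not measured in this assay. Compound 2 stands at 1340 nM in this assay, the lowest of the two numbers available, while compound 3 sits at 2850 nM. For the measured compounds named here, the only measured step, a 2.1-fold higher number from compound 2 to compound 3 (0.33 log units; beyond the scatter), alters the amine on the saturated chain carbon bound to an aromatic carbon and leaves the benzyl group untouched.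

Compound 4 `CN(C)Cc1ccc2nc(NC(=O)N/N=C/c3cn(Cc4cccc(Cl)c4)c4ccccc34)sc2c1` differs from compound 2 in another place: chloro in place of hydrogen on an aromatic carbon, so the benzyl becomes 3-chlorobenzyl. Going by the values given here, no measured step touches this ring, and so nothing in the data says whether a chlorine there raises or lowers the number. The expectation is therefore a step of roughly nothing beyond the scatter, a 1.1-fold lower number from compound 2 to compound 4 (0.05 log units; within the scatter). Compound 4 is expected near 1200 nM, with a range from 500 nM to 3000 nM.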

Compound 4, half-maximal inhibitory concentration: 1140 nM
Compound 4: the middle estimate sits 1.1-fold (0.02 log units) above what was measured; low and high end bracket the measured number.
By their numbers in this assay, from the lowest: compounds 4 and 2 (each within the scatter of the next); then compound 3.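

The benzyl ring had not been touched by any earlier step, and it now gives its first reading: in this assay, the change from benzyl to 3-chlorobenzyl gives a 1.2-fold lower number from compound 2 to compound 4 (0.07 log units; within the scatter). For the compounds shown here, this position therefore takes a chlorine with no change beyond the usual scatter, whereas the amine change, a 2.1-fold higher number from compound 2 to compound 3 (0.33 log units; beyond the scatter), remains the only step that lies beyond it. No measurement is available that would explain why the chlorine leaves the number within the scatter.

The compounds shown leave open whether a different group on this ring, such as methoxy or a carboxylic acid, would move the number. They also leave open whether the chlorine would give the same result with 4-methylpiperidin-1-yl in place of dimethylamino.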